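A few compounds are considered here, and "the series" means these few. Any claim that something is new, unique, unknown or untested is made for them only; others in the source may bear on it.

Compound 1 `COc1ccc(/C=C/C(=O)c2c(C)cc(O)c(C(=O)/C=C/c3ccc(OC)cc3)c2-c2ccc(OCc3ccccc3)cc2)cc1` was tested in an ADME assay on HEK293 cells (Homo sapiens) for cytotoxicity, read by MTT assay, with a stated time of 24 h (a higher number here means a weaker inhibitor, a lower number a stronger inhibitor), where compound 1 gives 28000 nM. A second compound, compound 2 `Cc1cc(O)c(C(=O)/C=C/c2ccc(OCc3ccccc3)cc2)c(-c2ccc(Br)cc2)c1C(=O)/C=C/c1ccc(OCc2ccccc2)cc1`, gives 25000 nM in this assay; the two numbers lie within the usual scatter of each other, so nothing separates them. Compound 3 `COc1ccc(/C=C/C(=O)c2c(C)cc(O)c(C(=O)/C=C/c3ccc(OC)cc3)c2-c2ccccc2)cc1` is a close relative of compound 1 that has not yet been measured. The change that turns compound 1 into compound 3 is hydrogen in place of benzyloxy on an aromatic carbon, a hydrogen in place of benzyloxy on an aromatic carbon. Among the compounds with values here, no measured pair shows what such a change does in this assay, so there is no step to lean on. The expectation for compound 3 is a step of a 1.1-fold lower number from compound 1 to compound 3 (0.05 log units; within the scatter) that is small and not clearly beyond the scatter in either direction. Compound 3 is therefore estimated to give 25000 nM in this assay, with a likely range from 10000 nM to 60000 nM.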

Compound 3, half-maximal inhibitory concentration: "not active" (no number reported)
Compound 3 has no reported number here, and the estimate cannot be compared.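

Within the data shown here, compound 3 is reported as "not active" without a number, so no step from compound 1 to compound 3 can be read. Going by these compounds, what swapping benzyloxy for hydrogen does in this assay stays open, and no available evidence bears on this result.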